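The compounds below may be only part of what the source reports. "The series", "measured", "known", "first", "only" and "open" are said of these compounds alone.

Measured so far:
compound 1, `CN1CCC(c2ccc3c(c2)oc(=O)n3C(=O)NCCCCc2ccccc2)CC1=O`, 105 nM
compound 2, `CC(C)CNC(=O)n1c(=O)oc2cc(C3CCCCN3C)ccc21`, 1010 nM
compound 3, `COCCCNC(=O)n1c(=O)oc2cc(-c3ccc(F)cc3)ccc21`, 2600 nM

These three compounds were tested in an assay on HEK293 cells for inhibition of acid ceramidase (Homo sapiens), read by fluorescence, with stated times of 10 min and 3 h; on this read-out lower numbers stand for stronger inhibition and higher numbers for weaker inhibition. Compound 1 gives the lowest number of the three. Its nearest neighbour, compound 2, sits beyond the usual scatter of the measurement, and compound 3 lies further still, so compound 1 stands alone at the strong end of this small set.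

The next compound, compound 4, `CN1CCN(c2ccc3c(c2)oc(=O)n3C(=O)NCCCCc2ccccc2)CC1=O`, keeps the whole of compound 1 apart from one place: 4-methyl-3-oxopiperazin-1-yl in place of 1-methyl-2-oxopiperidin-4-yl on an aromatic carbon. The ring that leaves and the ring that enters are of the same size and carry the same number of heavy atoms; what changes is one ring carbon giving way to a nitrogen, and with it the point where the ring is fastened to the core. Within the data shown here, no measured pair shows this exact change, so there is nothing to lean on but the values of compound 1 and its neighbours. A modest shift is expected, likely toward a higher number, but not far outside the scatter. For compound 4 the expected outcome in this assay is 180 nM, within 60 nM to 550 nM, meaning an expected step of a 1.7-fold higher number from compound 1 to compound 4 (0.23 log units; within the scatter).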

Compound 4, half-maximal inhibitory concentration in the acid ceramidase assay: 92 nM
Beside the measured number, compound 4's estimate is 2.0-fold (0.29 log units) above it; the range from low to high includes it.
By their numbers in the acid ceramidase assay, from the lowest: compounds 4 and 1 (each within the scatter of the next); then compound 2; then compound 3.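

In the acid ceramidase assay, 4-methyl-3-oxopiperazin-1-yl in place of 1-methyl-2-oxopiperidin-4-yl on an aromatic carbon gives a 1.1-fold lower number from compound 1 to compound 4 (0.06 log units; within the scatter), so this position accepts the ring with the added nitrogen and the two compounds cannot be told apart on this read-out. In a physicochemical assay for solubility, read by HPLC, in phosphate buffer, measured as kinetic solubility, with a stated time of 1 h, at pH 7.4, tested at 250 uM (on this read-out higher numbers stand for higher solubility and lower numbers for lower solubility), the same change gives an at least 20-fold lower number from compound 1 to compound 4 (1.30 log units; beyond the scatter), so the two read-outs part ways at this position. In the physicochemical assay compound 1 gives 20000 nM. In the physicochemical assay compound 4 gives < 1000 nM, which is a limit of the assay and not a number.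

The compounds shown leave open whether another group on this aromatic carbon, such as a morpholine ring or a carboxylic acid, would hold the number in the acid ceramidase assay close to that of compound 1 while raising the number in the physicochemical assay. Among these compounds, with only this one pair, it also remains open whether the change behaves the same way when the 4-phenylbutyl chain of compound 1 is replaced by a shorter chain.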